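The source may report more compounds than this note shows. Statements on the series, on what has been measured and on what is new or still open speak of the compounds shown alone.

Measured so far in a functional assay on BCG823 cells (Homo sapiens) for inhibition, read by MTT assay, with a stated time of 72 h; a higher number here means a weaker inhibitor, a lower number a stronger inhibitor:
- compound 1, `CN(C(=O)NC(=O)c1ccc(Cl)cc1Cl)c1nc(C(F)(F)F)c(C(=O)N/N=C/c2ccc(C(F)(F)F)cc2)s1`: 3.08 ug/mL
- compound 2, `CN(C(=O)NC(=O)c1cccc(C(F)(F)F)c1)c1nc(C(F)(F)F)c(C(=O)N/N=C/c2ccc(C(F)(F)F)cc2)s1`: 4.22 ug/mL

Compound 1 gives the lowest of the two numbers; its nearest neighbour is compound 2, and a 1.4-fold higher number from compound 1 to compound 2 (0.14 log units; within the scatter). That single step changes a group on a carbonyl carbon, far from the place that matters here, so it offers no guide. Compound 3, `Cc1nc(N(C)C(=O)NC(=O)c2ccc(Cl)cc2Cl)sc1C(=O)N/N=C/c1ccc(C(F)(F)F)cc1`, differs from compound 1 by methyl in place of trifluoromethyl on an aromatic carbon, the change sitting on an aromatic carbon of a five-membered aromatic ring with one nitrogen and one sulfur. Going by the values given here, no measured step touches that ring, so the expectation rests on compound 1 alone, with a wide range. Compound 3 is therefore estimated at 4.5 ug/mL, between 1.5 ug/mL and 14 ug/mL, meaning an expected 1.5-fold higher number from compound 1 to compound 3 (0.16 log units; within the scatter).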

Compound 3, half-maximal inhibitory concentration: 38 ug/mL
For compound 3 the middle estimate is 8.4-fold (0.93 log units) below the measured one, and the stated range ends below it.
By their numbers in this assay, from the lowest: compounds 1 and 2 (each within the scatter of the next); then compound 3.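

In this assay, the group on this aromatic carbon of the five-membered ring clearly counts: methyl in place of trifluoromethyl brings a 12-fold higher number from compound 1 to compound 3 (1.09 log units; beyond the scatter), a large step, whereas the earlier change on a carbonyl carbon stayed within the scatter. Nothing measured here explains this rise in the number. As far as these compounds go, whether an ethyl group, a chlorine atom or an amine on this carbon would read closer to compound 1 or to compound 3 remains open. So does whether the step would be as large with the 3-(trifluoromethyl)phenyl of compound 2 on the carbonyl carbon.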